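Swapping methyl for hydrogen on a ring oxygen, in two cores

The source may report more compounds than this note shows. Statements on the series, on what has been measured and on what is new or still open speak of the compounds shown alone.

Compound 1 `COc1cc(-c2nn(-c3cccc(NC(=O)Nc4cc(C(F)(F)F)cc(C(F)(F)F)c4)c3)cc2-c2ccncc2)ccc1Cl`: 1520 nM
Compound 2 `O=C(Nc1cccc(-n2cc(-c3ccncc3)c(-c3ccc(Cl)c(O)c3)n2)c1)Nc1cc(C(F)(F)F)cc(C(F)(F)F)c1`: 1400 nM
Compound 3 `COc1cc(-c2nn(-c3cccc(NC(=O)Nc4ccc(Cl)c(C(F)(F)F)c4)c3)cc2-c2ccncc2)ccc1Cl`: 4610 nM

In a functional assay on LOX IMVI cells (Homo sapiens) for inhibition, read by sulforhodamine B assay, with a stated time of 48 h (on this read-out lower numbers stand for stronger inhibition of growth and higher numbers for weaker inhibition of growth), compound 1 gives 1520 nM and compound 2 gives 1400 nM. The difference between them, (hydrogen in place of methyl on an oxygen on an aromatic ring), made a step of a 1.1-fold lower number from compound 1 to compound 2 (0.04 log units; within the scatter). Compound 3 gives 4610 nM in this assay; how its core differs from that of compound 1 is not broken down here. Compound 4 `O=C(Nc1cccc(-n2cc(-c3ccncc3)c(-c3ccc(Cl)c(O)c3)n2)c1)Nc1ccc(Cl)c(C(F)(F)F)c1` is not yet measured and differs from compound 3 by hydrogen in place of methyl on an oxygen on an aromatic ring, the same change as before, at the same kind of place. Because the earlier step was a 1.1-fold lower number from compound 1 to compound 2 (0.04 log units; within the scatter), the step from compound 3 to compound 4 is expected to be about as small, a 1.1-fold lower number from compound 3 to compound 4 (0.04 log units; within the scatter). Compound 4 is therefore estimated at 4200 nM in this assay, with a range from 2000 nM to 9000 nM expected.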

Compound 4, concentration for total growth inhibition: 1150 nM
For compound 4 the middle estimate is 3.7-fold (0.56 log units) above the measured one; the whole stated range lies above it.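

Replacing methoxy with hydroxy gave a 4.0-fold lower number from compound 3 to compound 4 (0.60 log units; beyond the scatter) in this assay, so the step did not carry over at the same size from the core of compound 1 to the core of compound 3: the same change on two cores in this assay, a 1.1-fold lower number (0.04 log units; within the scatter) from compound 1 to compound 2 and a 4.0-fold lower number (0.60 log units; beyond the scatter) from compound 3 to compound 4, 3.7-fold (0.57 log units) apart, beyond the scatter of two such steps

The size of this step therefore depends on the rest of the molecule, and the step on one core would have been a poor guide to the step on the other. These two pairs do not show why the steps differ, or what size the step would take on any further core.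

Still open, as far as these compounds go, is how an ethyl group or a longer chain on that oxygen would compare with methyl and hydrogen. From the compounds shown here alone, an amine in place of the hydroxy is equally open.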